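Aryl ether in place of carbamate at the side chain

This account rests on a few compounds, and the source may have more. Where it says the series, first, only, none or still open, it means among the compounds named here.

The measured compounds so far:
compound 1, `COc1nc(C)c(Nc2nc(Cl)cn([C@H](COC(=O)c3ccccc3)C3CC3)c2=O)cc1C`, 1.5 nM
compound 2, `COc1nc(C)c(Nc2nc(Cl)cn([C@H](COC(=O)Nc3cc(Cl)cc(Cl)c3)C3CC3)c2=O)cc1C`, 1.7 nM
compound 3, `CCCCNC(=O)OC[C@H](C1CC1)n1cc(Cl)nc(Nc2cc(C)c(OC)nc2C)c1=O`, 4.7 nM

In an assay on frontal cortex for displacement of a labelled ligand from corticotropin-releasing factor receptor 1 (Rattus norvegicus), with a stated time of 2 h (a higher number here means a weaker inhibitor, a lower number a stronger inhibitor), compound 2 stands second highest of the three numbers; its nearest neighbour is compound 1 with a 1.1-fold higher number from compound 1 to compound 2 (0.05 log units; within the scatter), its furthest compound 3 with a 2.8-fold higher number from compound 2 to compound 3 (0.44 log units; beyond the scatter). The shared core of compound 2 is kept in compound 4, `COc1nc(C)c(Nc2nc(Cl)cn([C@H](COc3ccc(C(F)(F)F)cn3)C3CC3)c2=O)cc1C`, where the change is 5-(trifluoromethyl)pyridin-2-yl in place of (3,5-dichlorophenyl)carbamoyl on an oxygen on a saturated carbon. Among the measured compounds shown here, two measured steps bear on this end of the side chain: the step of a 1.1-fold higher number from compound 1 to compound 2 (0.05 log units; within the scatter) and the modest step of a 2.8-fold higher number from compound 2 to compound 3 (0.44 log units; beyond the scatter). Neither replaces the carbamoyl group outright, so the change to compound 4 goes beyond them. Given that this region has only shifted modestly so far, compound 4 is expected to give 3 nM in this assay, a range of 1 nM to 10 nM, meaning an estimated step of a 1.8-fold higher number from compound 2 to compound 4 (0.25 log units; within the scatter).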

Compound 4, half-maximal inhibitory concentration: 1.6 nM
Beside the measured number, compound 4's estimate is 1.9-fold (0.27 log units) above it; low and high end bracket the measured number.
By their numbers in this assay, from the lowest: compounds 1, 4 and 2 (each within the scatter of the next); then compound 3.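

In this assay, the whole carbamoyl group can be replaced: 5-(trifluoromethyl)pyridin-2-yl on the oxygen, with no carbonyl and no amide hydrogen, gives a 1.1-fold lower number from compound 2 to compound 4 (0.03 log units; within the scatter). The benzoyl group compares the same way, with a 1.1-fold higher number from compound 1 to compound 4 (0.03 log units; within the scatter), so among these compounds only the butylcarbamoyl group stands apart, with a 2.9-fold lower number from compound 3 to compound 4 (0.47 log units; beyond the scatter).

Going by these compounds, whether a saturated alkyl chain on that oxygen, or an amine or a carboxylic acid on the pyridine ring, would give a similar number remains open. Nothing given here explains why these different groups give such close numbers.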